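The source may report more compounds than this note shows. Statements on the series, on what has been measured and on what is new or still open speak of the compounds shown alone.

Measured so far in an ADME assay on 184B5 cells (Homo sapiens) for cytotoxicity, read by MTT assay, with a stated time of 72 h; on this read-out lower numbers stand for stronger inhibition of growth and higher numbers for weaker inhibition of growth:
- compound 1 `CCCOC(=O)Nc1ccc([Se]C#N)cc1`, 9100 nM
- compound 2 `O=C(Nc1ccc([Se][Se]c2ccc(NC(=O)OCc3ccccc3)cc2)cc1)OCc1ccccc1`, 5800 nM
- compound 3 `CCCCCCOC(=O)Nc1ccc([Se][Se]c2ccc(NC(=O)OCCCCCC)cc2)cc1`, 9800 nM

Compound 1 is the only selenocyanate with a single aryl unit among the three measured; compound 2 and compound 3 are the diselenide pairs. On the numbers, compound 1 sits together with the other two: the nearer is compound 3 and the farther is compound 2, and both distances lie within the usual scatter, so no order among the three can be read from these values.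

The next compound in the series is compound 4 `N#C[Se]c1ccc(NC(=O)Oc2ccccc2)cc1`, not yet measured in this assay. It differs from compound 1 in one place: phenyl in place of propyl on an oxygen next to a carbonyl group.

Among the measured compounds shown here, no step between two measured compounds gives a handle on this change. Both carbamate esters of the diselenides leave the numbers within the scatter of compound 1, which suggests the ester group is not a strong driver here. The expectation for the step of a 1.1-fold lower number from compound 1 to compound 4 (0.06 log units; within the scatter) is therefore none beyond the scatter, in either direction. Compound 4 is expected to give about 8000 nM in this assay, with a range from 3000 nM to 25000 nM.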

Compound 4, concentration for total growth inhibition: 22700 nM
The estimate for compound 4 lay 2.8-fold (0.45 log units) below the measured number; the measured number falls inside the stated range.
By their numbers in this assay, from the lowest: compounds 2, 1 and 3 (each within the scatter of the next); then compound 4.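

In this assay the place on the oxygen next to a carbonyl group proves not to be silent: phenyl in place of propyl gives a 2.5-fold higher number from compound 1 to compound 4 (0.40 log units; beyond the scatter) and so moves toward weaker inhibition of growth. Among the compounds shown here, the earlier compounds offered no pair differing in one place, so this is the first reading of this position, and it is a modest step resting on a single pair. Nothing at hand accounts for the step.

Still open, on these data alone, is whether the step follows the aromatic ring itself or simply the larger group, and a cyclohexyl ester in the same place on the core of compound 1 would separate the two. Also open, as far as these compounds go, is whether a phenyl ring carrying an amine or a carboxylic acid would keep the same direction.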